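This account rests on a few compounds, and the source may have more. Where it says the series, first, only, none or still open, it means among the compounds named here.

Measured compounds:
- compound 1 `O=C(Nc1ccccc1)c1ccc(/N=N\c2c[nH]c3ccccc23)cc1` — 147000 nM
- compound 2 `Cc1ccc(C)c(NC(=O)c2ccc(/N=N\c3c[nH]c4ccccc34)cc2)c1` — 29900 nM
- compound 3 `O=C(Nc1ccc([N+](=O)[O-])cc1)c1ccc(/N=N\c2c[nH]c3ccccc23)cc1` — 54500 nM

In a functional assay on MCF7 cells (Homo sapiens) for inhibition, read by MTT assay, with a stated time of 72 h (a higher number here means a weaker inhibitor, a lower number a stronger inhibitor), compound 2 stands at the lowest of the three numbers; the step of a 1.8-fold higher number from compound 2 to compound 3 (0.26 log units; within the scatter) lies within the scatter, whereas a 4.9-fold lower number from compound 1 to compound 2 (0.69 log units; beyond the scatter) lies beyond it. Compound 4 `Cc1cccc(NC(=O)c2ccc(/N=N\c3c[nH]c4ccccc34)cc2)c1` differs from compound 2 by hydrogen in place of methyl on an aromatic carbon. Within the data shown here, the one measured step that bears on this is a 4.9-fold lower number from compound 1 to compound 2 (0.69 log units; beyond the scatter), which put both methyls in place at once; taking one of them away again is expected to undo part of that step, so a modest rise in this assay is expected, short of the full return to the value of compound 1. The expected step is a 1.8-fold higher number from compound 2 to compound 4 (0.26 log units; within the scatter). Compound 4 is therefore estimated at 55000 nM, with a range of 22000 nM to 130000 nM.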

Compound 4, half-maximal inhibitory concentration: 73400 nM
Compound 4: the middle estimate sits 1.3-fold (0.13 log units) below what was measured; the measured number falls inside the stated range.
By their numbers in this assay, from the lowest: compounds 2, 3, 4 and 1 (each within the scatter of the next, the first and the last beyond it).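

In this assay, the methyl ortho to a large group on the 2,5-dimethylphenyl of compound 2 accounts for a step beyond the scatter (a 2.5-fold higher number from compound 2 to compound 4 (0.39 log units; beyond the scatter)), so this single position matters on its own. The 3-methylphenyl group that remains is not separated from phenyl (a 2.0-fold lower number from compound 1 to compound 4 (0.30 log units; within the scatter)) or from 4-nitrophenyl (a 1.3-fold higher number from compound 3 to compound 4 (0.13 log units; within the scatter)), both steps lying within the scatter. Nothing available explains the effect of this methyl.

Open, going by these compounds, is whether a methyl at this position needs the second methyl to give the low number of compound 2. Also open, on these data alone, is whether a chlorine or a methoxy group there would give a similar step.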